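A Neopentyl Swap on a Quickly Removed Compound

This account rests on a few compounds, and the source may have more. Where it says the series, first, only, none or still open, it means among the compounds named here.

In an ADME assay on liver for metabolic stability, with Liver microsome (Homo sapiens) as the target, read by LC-MS, using microsomes (a higher number here means faster removal of the compound, a lower number slower removal), compound 1 (`O=C(NCc1cc(Cl)ccc1-n1cnnn1)[C@@H]1C[C@@H]2C[C@@H]2N1C(=O)[C@H](O)c1cccc(Cl)c1`) gives > 500 mL.min-1.g-1, a limit of the assay. Compound 1 thus stands alone at the limit of > 500 mL.min-1.g-1 in this assay, at which 1 of the 3 values shown sits. Compound 2 (`CC1(C[C@@H](O)C(=O)N2N=CC[C@H]2C(=O)NCc2cc(Cl)ccc2-n2cnnn2)CC1`) gives < 12 mL.min-1.g-1, also a limit. Compound 3 (`CCCC[C@@H](O)C(=O)N1N=CC[C@H]1C(=O)NCc1cc(Cl)ccc1-n1cnnn1`) gives < 12 mL.min-1.g-1, again a limit. Within the data shown here, these two, on another core, share (the limit of < 12 mL.min-1.g-1 in this assay, at which 2 of the 3 values shown sit), and the only measured step is a step that the two limits leave unreadable from compound 2 to compound 3. Compound 4 (`CC(C)(C)C[C@@H](O)C(=O)N1[C@H](C(=O)NCc2cc(Cl)ccc2-n2cnnn2)C[C@@H]2C[C@@H]21`) keeps the core of compound 1 and differs by neopentyl in place of 3-chlorophenyl on a saturated chain carbon bound to a carbonyl carbon and an oxygen on a saturated carbon, with neopentyl in place of 3-chlorophenyl. Among the measured compounds shown here, no measured step shows this change directly. Compound 3, with its propyl-bearing chain, sits at the limit < 12 mL.min-1.g-1, which gives the only hint of a fall. A large fall is expected, an at least 8.3-fold lower number from compound 1 to compound 4 (0.92 log units; beyond the scatter). Compound 4 is estimated at 60 mL.min-1.g-1, within 12 mL.min-1.g-1 to 300 mL.min-1.g-1.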

Compound 4, intrinsic clearance in microsomes: 40 mL.min-1.g-1
For compound 4 the middle estimate is 1.5-fold (0.18 log units) above the measured one, within the range that was stated.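

In this assay, neopentyl in place of 3-chlorophenyl gives an at least 12-fold lower number from compound 1 to compound 4 (1.09 log units; beyond the scatter), which shows that this position strongly affects the read-out on the core of compound 1. Compound 4 gives a measured number, 40 mL.min-1.g-1, rather than a limit of the assay. The true size of the step stays open, since it starts from a limit: the limit of > 500 mL.min-1.g-1 in this assay, at which 1 of the 4 values shown sits.

The step between the two compounds on the other core cannot be read, so it says nothing about chain shape. A cyclohexyl or an unsubstituted phenyl group at this place on the same core would show whether the fall follows the loss of the chlorine, of the aromatic ring, or of both.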